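The compounds below may be only part of what the source reports. "The series", "measured", "known", "first", "only" and "open" are said of these compounds alone.

Measured compounds:
Compound 1 `CCCN(CC1CC1)c1nc(C)nc(N(CC)c2ccc(N(C)C)cc2C(F)(F)F)n1` gives 5 nM in an assay on isolated protein for binding affinity to corticotropin-releasing factor receptor 1 (Homo sapiens); on this read-out lower numbers stand for stronger inhibition and higher numbers for weaker inhibition.
Compound 2 `CCCN(CCC)c1nc(C)nc(N(CC)c2ccc(C(C)C)cc2Br)n1` gives 4 nM in this assay.
Compound 3 `CCN(CC)c1cc(C)nc(N(CC)c2c(Br)cc(Br)cc2OC)n1` gives 31 nM in this assay.

Compound 1 stands second highest of the three numbers. Compound 2 lies nearest, with a slightly lower number that sits within the scatter, while compound 3 stands furthest, with a higher number that lies beyond the scatter. For the measured compounds named here, no single-point step between measured compounds is available.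

Compound 4 `CCCN(CCC)c1nc(C)nc(N(CC)c2ccc(N(C)C)cc2C(F)(F)F)n1` has not yet been measured. It differs from compound 1 by ethyl in place of cyclopropyl on a saturated chain carbon bound to a nitrogen on an aromatic ring, giving the same dipropylamino arrangement carried by compound 2. Since compound 2, with that group, gives 4 nM, no step beyond the scatter is expected in this assay. Compound 4 is expected to give 5 nM, with a range of 2 nM to 12 nM, a step of no change at the digits printed from compound 1 to compound 4 (within the scatter) that is an estimate only.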

Compound 4, inhibition constant: 6 nM
Compound 4: the middle estimate sits 1.2-fold (0.08 log units) below what was measured; the measured number falls inside the stated range.
By their numbers in this assay, from the lowest: compounds 2, 1 and 4 (each within the scatter of the next); then compound 3.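

In this assay, the exchange of cyclopropyl for ethyl on a saturated chain carbon bound to a nitrogen on an aromatic ring gives a 1.2-fold higher number from compound 1 to compound 4 (0.08 log units; within the scatter). For the compounds shown here, this is the first single-place comparison at this position, and it shows that, on the core of compound 1, the cyclopropylmethyl group can give way to propyl without a step beyond the scatter. Nothing measured here accounts for this result. The compounds shown leave open how a longer chain such as butyl, or a chain ending in a methoxy group or an amine, would read at this place.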